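Shortening the hydroxyalkyl amide chain in the series

The compounds below may be only part of what the source reports. "The series", "measured", "known", "first", "only" and "open" are said of these compounds alone.

Measured so far in an assay on HEK293 cells for displacement of a labelled ligand from adenosine receptor A2b (Homo sapiens), read by scintillation counting, with a stated time of 30 min, tested at 10 uM; a lower number here means less inhibition, a higher number more inhibition at the concentration tested (going by the name of the read-out):
compound 1, `COCCNC(=O)c1cc2cccc(OC)c2oc1=N`: 43%
compound 2, `N=c1oc2ccc(Br)cc2cc1C(=O)NC1CCCC1`: 28%
compound 3, `COc1cccc2cc(C(=O)NCCCCCO)c(=N)oc12`: > 70%

Compound 3 stands highest of the three values shown, but its value is a limit of this assay and not a number, as the limit of > 70% in this assay, at which 1 of the 3 values shown sits, records. Going by the values given here, the single measured step that reaches compound 3 is a number at least 27 percentage points higher from compound 1 to compound 3 (beyond the scatter); the change of methoxy to 3-hydroxypropyl carried the series from a middling inhibition up to the limit.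

Compound 4, `COc1cccc2cc(C(=O)NCCO)c(=N)oc12`, has not been measured. It differs from compound 3 by hydroxy in place of 3-hydroxypropyl on a saturated chain carbon, two bonds along the chain from an amide-type nitrogen. Read one bond further out, 5-hydroxypentyl becomes 2-hydroxyethyl, so the chain returns to the length it has in compound 1, with hydroxy now where compound 1 carries methoxy. The step from compound 1 to compound 3 was at least modest, and this change runs largely against it, so part of that gain is expected to be given back, though the retained hydroxy leaves the size uncertain. The expected step is a number at least 20 percentage points lower from compound 3 to compound 4 (beyond the scatter). Compound 4 is therefore estimated at 50%, within a range of 30% to 72%.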

Compound 4, a percentage reported as inhibition, at one concentration (the size of the read-out at that concentration, not a potency): 65%
Compound 4: middle estimate off by 15 percentage points, on the low side, within the range that was stated.
By their numbers in this assay, from the lowest: compound 2; then compound 1; then compound 4. At a limit, above all of these: compound 3.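

In this assay, the hydroxy itself now stands apart from chain length: with the chain held at the length of compound 1, the free hydroxy in place of the methoxy gives a number 22 percentage points higher from compound 1 to compound 4 (beyond the scatter), so the terminal methyl alone accounts for a real difference. Cutting 5-hydroxypentyl back to 2-hydroxyethyl gives a number at least 5 percentage points lower from compound 3 to compound 4 (that floor lies within the scatter), so no loss from the shorter chain can be claimed on these numbers, and the gain seen earlier with a number at least 27 percentage points higher from compound 1 to compound 3 (beyond the scatter) can no longer be credited to the longer chain alone. Compound 3 reads as a limit of the assay and not as a number, so the true size of the chain-length step stays unknown: the limit of > 70% in this assay, at which 1 of the 4 values shown sits.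

Still open, as far as these compounds go, is how the response runs across chains of intermediate length, and whether anything separates the long and short hydroxy chains once compound 3 has a number of its own. Also open, from the compounds shown here alone, is whether an amine or a carboxylic acid in place of the hydroxy would hold the level of compound 4 on the same chain.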